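Cytotoxicity notes on three measured compounds and one pending

This account rests on a few compounds, and the source may have more. Where it says the series, first, only, none or still open, it means among the compounds named here.

Measured so far:
- compound 1 `C[Se]C(=O)c1cccc(C(=O)[Se]C)n1`: 17900 nM
- compound 2 `CC(C)(C)C(=O)C[Se]C(=O)c1ccc(Cl)cc1`: 8100 nM
- compound 3 `C[Se]C(=O)c1ccc(C(=O)[Se]C)cc1`: 61500 nM

In an ADME assay on MRC5 cells (Homo sapiens) for cytotoxicity, read by MTT assay, with a stated time of 24 h (on this read-out higher numbers stand for weaker inhibition and lower numbers for stronger inhibition), compound 2 gives the lowest of the three numbers. Compound 1 sits nearest to it, with a number higher by a margin that lies beyond the usual scatter, and compound 3 lies furthest, with a number higher by a margin well beyond the scatter. Among the compounds with values here, no pair among the three measured compounds differs in only one place, so no measured step of a single change is available within the set.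

Compound 4 `CC(=O)C[Se]C(=O)c1ccc(Cl)cc1` is the next to be measured in this assay. Its difference from compound 2 is methyl in place of tert-butyl on a carbonyl carbon. Within the data shown here, no measured pair shows what this change does, so the expectation rests on compound 2 alone, whose value of 8100 nM is the anchor. The step is expected to be small, most likely within the scatter, with a slight lean toward a higher number: a 1.2-fold higher number from compound 2 to compound 4 (0.09 log units; within the scatter). For compound 4 the estimate is 10000 nM, with a range from 4000 nM to 25000 nM.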

Compound 4, half-maximal inhibitory concentration: 5350 nM
The estimate for compound 4 lay 1.9-fold (0.27 log units) above the measured number; low and high end bracket the measured number.
By their numbers in this assay, from the lowest: compounds 4 and 2 (each within the scatter of the next); then compound 1; then compound 3.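

In this assay, within the data shown here, the step of a 1.5-fold lower number from compound 2 to compound 4 (0.18 log units; within the scatter) gives the first measured reading at this position. Methyl in place of tert-butyl on a carbonyl carbon takes the group from 4 heavy atoms to 1, yet the number stays within the scatter, so this pair shows no measurable change in this read-out despite the smaller group. Nothing measured here accounts for this result.

Whether a longer chain, a phenyl ring, an amine or a carboxylic acid on this carbonyl carbon would move the number beyond the scatter remains open, since methyl and tert-butyl are the only groups shown there. From the compounds shown here alone, whether the same change would behave alike in other surroundings also remains open, as this single pair shares its core with neither compound 1 nor compound 3.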